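A few compounds are considered here, and "the series" means these few. Any claim that something is new, unique, unknown or untested is made for them only; others in the source may bear on it.

Of the compounds shown here, two built on one shared core have been measured in an assay for inhibition of Indoleamine 2,3-dioxygenase 1 (Homo sapiens), with stated times of 10 min and 60 min; a lower number here means a stronger inhibitor, a higher number a weaker inhibitor. Compound 1, `Oc1ccc(CNc2cc(C(F)(F)F)cc3[nH]ncc23)cc1`, carries a hydroxyl on its outer benzene ring, and in this assay compound 1 gives 36700 nM. Compound 2, `OC1CCCC(Nc2cccc(CNc3cc(C(F)(F)F)cc4[nH]ncc34)c2)C1`, carries instead a (3-hydroxycyclohexyl)amino group on that ring. Among the measured compounds shown here, for compound 2 this assay reports no number, only a limit, > 100000 nM, and it is the only one of the two compounds that sits at the limit of > 100000 nM in this assay, at which 1 of the 2 values shown sits. Compound 2 therefore stands at the weak end of what has been seen so far.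

Compound 3, `Nc1cccc(CNc2cc(C(F)(F)F)cc3[nH]ncc23)c1`, has not yet been measured. It differs from compound 2 by hydrogen in place of 3-hydroxycyclohexyl on a nitrogen on an aromatic ring, so that a plain amino group remains. The step from compound 2 to compound 3 is expected to bring a gain, since compound 1 gives 36700 nM with a small group in the same place. The expected size of this step is an at least 2.0-fold lower number from compound 2 to compound 3 (0.30 log units; that floor lies within the scatter). Compound 3 is thus estimated at 50000 nM, within a range from 15000 nM to 150000 nM.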

Compound 3, half-maximal inhibitory concentration: > 100000 nM
Compound 3 gave a limit, no number (the forecaster's own chance of this, stated with the estimate: 30%); middle value at least 2.0-fold (0.30 log units) from the limit.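

In this assay compound 3 gives no number either, only a limit, > 100000 nM. The step between compound 2 and compound 3 therefore cannot be read, and taking the 3-hydroxycyclohexyl group off the nitrogen on the aromatic ring does not yield a measurable value, so the plain amino group cannot be ranked against the (3-hydroxycyclohexyl)amino group. The readable comparison is an at least 2.7-fold higher number from compound 1 to compound 3 (0.43 log units; beyond the scatter), which is beyond the usual scatter and shows that 3-aminophenyl in place of 4-hydroxyphenyl, on the saturated chain carbon bound to a nitrogen on an aromatic ring, gives a weaker result even with the cyclohexyl ring gone.

That step changes both the group on the outer ring and its number in the name, so the compounds shown cannot say which of the two matters; a 4-aminophenyl or a 3-hydroxyphenyl group would separate them. How much weaker compound 2 and compound 3 really are, and whether they differ at all, also stays open: the limit of > 100000 nM in this assay, at which 2 of the 3 values shown sit.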